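The compounds below may be only part of what the source reports. "The series", "measured", "known", "first", "only" and "open" are said of these compounds alone.

Measured compounds:

Compound 1 `CO[C@H]1CC[C@H](Nc2cc(NCc3cnccc3C(F)(F)F)ncc2C#N)CC1` gives > 10000 nM in an assay on isolated protein for inhibition of protein kinase C delta type (Homo sapiens), read by TR-FRET, with a stated time of 2 h; on this read-out higher numbers stand for weaker inhibition and lower numbers for stronger inhibition; that value is a limit of this assay, not a number.
Compound 2 `N#Cc1cnc(NCc2ccccc2C(F)(F)F)cc1N[C@H]1C[C@H](C(N)=O)C1` gives > 10000 nM in this assay, again a limit rather than a number.
Compound 3 `CC1(C)C[C@H](Nc2cc(NCc3cnccc3C(F)(F)F)ncc2C#N)CC(C)(C)[C@@H]1O` gives 700 nM in this assay.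

Compound 1 therefore stands at the limit of > 10000 nM in this assay, at which 2 of the 3 values shown sit, with nothing below it to set it apart, and only compound 3 among the three has a measured number.

Compound 4 `CC1(C)C[C@@H](Nc2cc(NCc3cnccc3C(F)(F)F)ncc2C#N)CC[C@H]1O` is not yet measured. It differs from compound 1 in one place: 4-hydroxy-3,3-dimethylcyclohexyl in place of 4-methoxycyclohexyl on a nitrogen on an aromatic ring. Compound 3 carries a related hydroxy-bearing dimethyl-substituted ring on the same nitrogen and reaches 700 nM. Compound 1 itself has no measured number, so the change is expected to move toward stronger inhibition, beyond the usual scatter. The step from compound 1 to compound 4 is estimated at an at least 5.0-fold lower number from compound 1 to compound 4 (0.69 log units; beyond the scatter). Compound 4 is expected to give about 2000 nM in this assay, with a likely range from 500 nM to 10000 nM.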

Compound 4, half-maximal inhibitory concentration: 2400 nM
Estimate against measurement, compound 4: 1.2-fold (0.08 log units) below, and the stated range covers the measured number.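

In this assay, among the compounds shown here, 4-hydroxy-3,3-dimethylcyclohexyl in place of 4-methoxycyclohexyl on this nitrogen gives an at least 4.1-fold lower number from compound 1 to compound 4 (0.61 log units; beyond the scatter), the first step at this position that can be read. The value of compound 1 is a limit and not a number, and the step therefore gives only a minimum size: the limit of > 10000 nM in this assay, at which 2 of the 4 values shown sit. Compound 4, at 2400 nM, is a second measured number for a hydroxy-bearing ring on this nitrogen, alongside compound 3 at 700 nM, and measurable inhibition here no longer rests on one compound.

Compound 4 changes the methoxy to a hydroxy and adds the two methyl groups at once, and the compounds shown do not tell which of these carries the step; a plain 4-hydroxycyclohexyl group would separate them. They also leave open how an amine or a carboxylic acid in place of the hydroxy would read.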